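Mirror-image pair in a canine kidney cell permeability assay

This account rests on a few compounds, and the source may have more. Where it says the series, first, only, none or still open, it means among the compounds named here.

Measured compounds:
compound 1, `Cc1cc(C)c(CN2CCc3c(Cl)cc([C@@H](CO)[C@@H]4CCOC4)c(Cl)c3C2=O)c(=O)[nH]1` — 3 10^-6 cm/s
compound 2, `COC(c1cc(Cl)c2c(c1Cl)C(=O)N(Cc1c(C)cc(C)[nH]c1=O)CC2)C1CCN(C2COC2)CC1` — 7 10^-6 cm/s; 7.9 10^-6 cm/s (2 entries)
compound 3, `COc1cc(C)[nH]c(=O)c1CN1CCc2c(Cl)cc([C@@H](O)C3COC3)c(Cl)c2C1=O` — 1.2 10^-6 cm/s

In an ADME assay on MDCK cells (Canis lupus familiaris) for permeability, read by LC-MS, with a stated time of 90 min, tested at 2 uM (a lower number here means that the compound crosses the layer more slowly, a higher number that the compound crosses the layer faster), compound 1 gives 3 10^-6 cm/s. Among the two compounds with a single number, compound 1 stands higher; compound 3 gives 1.2 10^-6 cm/s, a lower value beyond the scatter. Compound 2 was run more than once the several entries of compound 2 in this assay, 7 10^-6 cm/s; 7.9 10^-6 cm/s (2 entries) and therefore stands apart as a compound without a single number.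

Compound 4, `Cc1cc(C)c(CN2CCc3c(Cl)cc([C@H](CO)[C@H]4CCOC4)c(Cl)c3C2=O)c(=O)[nH]1`, has not yet been measured. Its relation to compound 1 is the two compounds have the same atoms and bonds and differ only in configuration as drawn: 2 of 2 stereo elements differ (all stereocentres are inverted: mirror images); a stereocentre at a saturated chain carbon is drawn S in compound 1 and R in compound 4; a stereocentre at a saturated ring carbon is drawn S in compound 1 and R in compound 4. The two compounds are mirror images with the same atoms and bonds. For the measured compounds named here, nothing among the measured compounds separates them, and no step between measured compounds exists to draw on. In this assay the expected step is no change at the digits printed from compound 1 to compound 4 (within the scatter), that is, none beyond the scatter. Compound 4 is therefore estimated at 3 10^-6 cm/s, with a range from 1.5 10^-6 cm/s to 6 10^-6 cm/s.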

Compound 4, apparent permeability: 2.9 10^-6 cm/s
The estimate for compound 4 lay 1.0-fold (0.01 log units) above the measured number, within the range that was stated.
By their numbers in this assay, from the lowest: compound 3; then compounds 4 and 1 (each within the scatter of the next).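

In this assay, inverting both the stereocentre at the saturated chain carbon and the stereocentre at the saturated ring carbon gives a 1.0-fold lower number from compound 1 to compound 4 (0.01 log units; within the scatter), so this read-out does not separate the two mirror images. For the compounds shown here, the earlier compounds offered no step at all, and this is the first pair in which a single kind of change can be read on its own, with the atoms and bonds held fixed: the fact that compounds 1 and 4 differ only in the configuration as drawn. At this position, then, the configuration as drawn leaves the number within the scatter when both stereocentres are inverted together.

From the compounds shown here alone, it remains open whether the number would also hold with only one of the two stereocentres inverted. Going by these compounds, it is equally open whether the mirror images would still agree with a carboxylic acid on the saturated chain carbon.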